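A few compounds are considered here, and "the series" means these few. Any claim that something is new, unique, unknown or untested is made for them only; others in the source may bear on it.

Values so far in a functional assay on DU-145 cells (Homo sapiens) for inhibition, read by trypan blue exclusion, with a stated time of 96 h; on this read-out lower numbers stand for stronger inhibition of growth and higher numbers for weaker inhibition of growth:

- compound 1 `O=C(/C(=C\c1ccc(Cl)c([N+](=O)[O-])c1)S(=O)(=O)c1ccc(Br)cc1)c1ccc(Br)cc1` gives 10000 nM
- compound 2 `COc1cccc(OC)c1/C=C(\C(=O)c1ccc(Br)cc1)S(=O)(=O)c1ccc(Br)cc1` gives 10000 nM
- compound 3 `O=C(/C(=C\c1ccc(F)cc1Cl)S(=O)(=O)c1ccc(Br)cc1)c1ccc(Br)cc1` gives 50000 nM

Compound 3 has the highest number of the three and is the weakest growth inhibitor in this small set. Both a 5.0-fold higher number from compound 1 to compound 3 (0.70 log units; beyond the scatter) and a 5.0-fold higher number from compound 2 to compound 3 (0.70 log units; beyond the scatter) lie beyond the scatter, whereas no change at the digits printed from compound 1 to compound 2 (within the scatter) stays within it.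

The next compound is compound 4 `O=C(/C(=C\c1ccc(Br)c([N+](=O)[O-])c1)S(=O)(=O)c1ccc(Br)cc1)c1ccc(Br)cc1`. The change is 4-bromo-3-nitrophenyl in place of 2-chloro-4-fluorophenyl on a double-bonded chain carbon bound to a double-bonded chain carbon.

The most relevant measurement is a 5.0-fold higher number from compound 1 to compound 3 (0.70 log units; beyond the scatter), read in reverse. Compound 1 carries 4-chloro-3-nitrophenyl, which differs from the entering group only in having chloro where compound 4 has bromo. Among the measured compounds shown here, no measured step exchanges these two halogens, so that difference remains untested. The step of a 5.0-fold higher number from compound 2 to compound 3 (0.70 log units; beyond the scatter) is of the same size and supports the direction, although its group is less similar.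

The expected change is a 5.0-fold lower number from compound 3 to compound 4 (0.70 log units; beyond the scatter), a modest move to a lower number in this assay. For compound 4 the estimated value is 10000 nM, with an expected range of 3000 nM to 30000 nM.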

Compound 4, concentration for 50% growth inhibition: 10000 nM
Compound 4: middle estimate and measured number agree at the digits printed; the measured number falls inside the stated range.
By their numbers in this assay, from the lowest: compounds 1, 2 and 4 (each within the scatter of the next); then compound 3.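

The exchange of halogens on the nitrophenyl group can now be read directly: in this assay, bromo in place of chloro on an aromatic carbon gives no change at the digits printed from compound 1 to compound 4 (within the scatter). On a double-bonded chain carbon bound to a double-bonded chain carbon, 4-bromo-3-nitrophenyl in place of 2-chloro-4-fluorophenyl gives a 5.0-fold lower number from compound 3 to compound 4 (0.70 log units; beyond the scatter), while in place of 2,6-dimethoxyphenyl it gives no change at the digits printed from compound 2 to compound 4 (within the scatter), so compound 3 alone stands apart from the other three compounds at this place. No measured evidence here bears on what sets 2-chloro-4-fluorophenyl apart from the other groups.

Still open, going by these compounds, is whether an amine or a carboxylic acid on the phenyl group at this place would move the number away from the level shared by compound 1, compound 2 and compound 4, and what changes elsewhere in the shared core, which is the same in all four compounds, would do. Also open is whether the chloro or the fluoro of 2-chloro-4-fluorophenyl accounts for the result of compound 3, with no phenyl group carrying only one of these two halogens among the compounds shown.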